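The source may report more compounds than this note shows. Statements on the series, on what has been measured and on what is new or still open speak of the compounds shown alone.

Measured so far:
compound 1 `CC(C)C[C@H](NC(=O)[C@H](C)NC(=O)c1cccnc1)C(=O)N[C@@H](CCCC[N+](C)(C)C)C(=O)N[C@@H](CO)C(N)=O` — 91000 nM
compound 2 `CC(C)C[C@H](NC(=O)[C@H](C)NC(=O)CCc1ccccc1)C(=O)N[C@@H](CCCC[N+](C)(C)C)C(=O)N[C@@H](CO)C(N)=O` — 26000 nM

Compound 1, in an assay on isolated protein for displacement of a labelled ligand from Chromobox protein homolog 7 (Homo sapiens), read by fluorescence polarization, with a stated time of 15 min (a higher number here means a weaker inhibitor, a lower number a stronger inhibitor), gives 91000 nM, the highest of the two numbers measured; its nearest neighbour is compound 2, which gives 26000 nM. Compound 3 `COc1ccc(S(=O)(=O)N[C@@H](C)C(=O)N[C@@H](CC(C)C)C(=O)N[C@@H](CCCC[N+](C)(C)C)C(=O)N[C@@H](CO)C(N)=O)cc1` is not yet measured. It differs from compound 1 in one place: (4-methoxyphenyl)sulfonyl in place of (pyridin-3-yl)carbonyl on an amine nitrogen.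

Within the data shown here, only one measured step bears on this end of the molecule. Replacing the nitrogen-containing ring with a phenethyl group gave a 3.5-fold lower number from compound 1 to compound 2 (0.54 log units; beyond the scatter). Among the measured compounds shown here, that step kept the carbonyl and changed the ring; the change to compound 3 swaps both the ring and the carbonyl for a sulfonyl, so no measured pair covers it directly. The expectation is therefore cautious: a carbon-only aromatic ring again, so a number somewhat lower than compound 1 is expected, a 1.8-fold lower number from compound 1 to compound 3 (0.26 log units; within the scatter). Compound 3 is estimated at 50000 nM, between 15000 nM and 160000 nM.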

Compound 3, half-maximal inhibitory concentration: > 250000 nM
Compound 3: a limit, no number; the forecaster's own chance of this, stated with the estimate: 20%; at least 5.0-fold (0.69 log units) between middle value and limit.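

Compound 3 gives a limit of the assay, not a number: the limit of > 250000 nM in this assay, at which 1 of the 3 values shown sits.

Changing the group on this amine nitrogen can therefore raise the number as well as lower it, with an at least 2.7-fold higher number from compound 1 to compound 3 (0.43 log units; beyond the scatter) and with an at least 9.6-fold higher number from compound 2 to compound 3 (0.98 log units; beyond the scatter). A six-membered aromatic ring of carbon only does not by itself give a lower number, since compound 2 and compound 3 both carry such a ring and lie on opposite sides of compound 1.

Compound 3 changes the sulfonyl and the ring together, so the compounds shown cannot tell which of the two goes with the higher number, and a (4-methoxyphenyl)carbonyl group on the same nitrogen would separate them. On these data alone, how far the number rises also stays open, as the limit gives no end value for either step.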